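The compounds below may be only part of what the source reports. "The series", "measured", "known", "first", "only" and "open" are said of these compounds alone.

Working notes on the series. Two compounds have been run in an ADME assay on cells (Peritoneal macrophage cell, Mus musculus, strain C57BL/6) for cytotoxicity, read by LDH release (a lower number here means a stronger inhibitor, a higher number a weaker inhibitor), so far. Compound 1 `Cc1ccc2[nH]c(C(=O)O)c(/C=N\NC(=O)c3ccncc3)c2c1` gives 25 ug/mL in this assay. Compound 2 `CCOC(=O)c1[nH]c2ccccc2c1/C=N\NC(=O)c1ccncc1` gives 16 ug/mL in this assay; this is the smaller of the two figures on hand, but the gap to compound 1 lies within the usual scatter, so no ordering between the two is claimed.

Compound 3 `CCOC(=O)c1[nH]c2ccc(C)cc2c1/C=N\NC(=O)c1ccncc1` is the next candidate for this assay. Relative to compound 2 the change is methyl in place of hydrogen on an aromatic carbon. Within the data shown here, no measured pair isolates this change: compound 1 also carries the methyl, yet differs from compound 3 elsewhere as well, so the pair of compound 1 and compound 2 shows only that their values sit within the scatter of each other. With nothing on record pointing in either direction, the step from compound 2 to compound 3 is expected to be no larger than the scatter, a 1.1-fold higher number from compound 2 to compound 3 (0.03 log units; within the scatter). For compound 3 the estimated value in this assay is 17 ug/mL, with a range from 9 ug/mL to 32 ug/mL.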

Compound 3, half-maximal inhibitory concentration: 15 ug/mL
Estimate against measurement, compound 3: 1.1-fold (0.05 log units) above; the range from low to high includes it.
By their numbers in this assay, from the lowest: compounds 3, 2 and 1 (each within the scatter of the next).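

The pair of compound 2 and compound 3 now isolates the methyl on this aromatic carbon: in this assay, methyl in place of hydrogen gives a 1.1-fold lower number from compound 2 to compound 3 (0.03 log units; within the scatter), so this single change has no readable effect on the number. Among these compounds, the pair of compound 1 and compound 3 isolates the other site for the first time: ethyl in place of hydrogen on the oxygen of the carboxylic acid gives a 1.7-fold lower number from compound 1 to compound 3 (0.22 log units; within the scatter), which is also no readable effect. Nothing on record offers an explanation for either step.

Going by these compounds, whether a chlorine or a methoxy on the same aromatic carbon would give a step beyond the scatter remains open. The same holds for a longer chain than ethyl on the ester oxygen, or an amide in place of the ester.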